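Oxazole for pyrazole at the fused ring of compound 2

This account rests on a few compounds, and the source may have more. Where it says the series, first, only, none or still open, it means among the compounds named here.

Compound 1 `Cc1n[nH]cc1-c1cccc2c1CCC2c1ncc[nH]1`: 91%
Compound 2 `Cn1cc(-c2cccc3c2CCC3c2ncc[nH]2)cn1`: 12%

In a functional assay on CHO cells for agonist activity at Alpha-1A adrenergic receptor (Homo sapiens), read by FLIPR and calcium flux (a lower number here means a smaller maximal response, a higher number a larger maximal response), compound 2 gives 12%, the lowest of the two numbers measured; its nearest neighbour is compound 1, which in this assay gives 91%. Going by the values given here, the one measured step, a number 79 percentage points lower from compound 1 to compound 2 (beyond the scatter), shows that changing the five-membered ring on the shared core moves the response a great deal.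

Compound 3 `c1cc(-c2ncco2)c2c(c1)C(c1ncc[nH]1)CC2` carries a different ring at the same place: 1,3-oxazol-2-yl in place of 1-methyl-1H-pyrazol-4-yl on an aromatic carbon. Among the compounds with values here, no measured step covers this exchange directly, since the step from compound 1 to compound 2 only exchanges one pyrazole for another. What that step does tell is that such exchanges at this position can shift this assay far beyond the scatter, in either direction as far as these data go.

With only compound 2 as anchor, compound 3 is expected to give 35%, within 5% to 85%, an expected step of a number 23 percentage points higher from compound 2 to compound 3 (beyond the scatter).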

Compound 3, largest response reached (Emax), in percent of the reference or control that the assay uses: 63%
Estimate against measurement, compound 3: 28 percentage points below, and the stated range covers the measured number.
By their numbers in this assay, from the lowest: compound 2; then compound 3; then compound 1.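

Replacing 1-methyl-1H-pyrazol-4-yl with 1,3-oxazol-2-yl on the aromatic carbon changes the result in this assay by a number 51 percentage points higher from compound 2 to compound 3 (beyond the scatter), so a large rise at this position can come from a change other than the exchange between the two pyrazoles. The leaving and entering groups are both five-membered aromatic rings with two hetero atoms, and they have the same counts of hydrogen-bond donors and acceptors, so those counts alone do not separate compound 2 from compound 3. The oxazole does not match the 3-methyl-1H-pyrazol-4-yl group, however: the result is a number 28 percentage points lower from compound 1 to compound 3 (beyond the scatter), which places compound 3 between the other two compounds, and no measurement available here explains why these rings differ.

The compounds shown leave open whether adding a methyl group to the 1,3-oxazol-2-yl ring would move the response closer to that of compound 1. They also leave open how this assay would respond if an amine, a carboxylic acid or a longer chain stood on the same aromatic carbon in place of a five-membered aromatic ring.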